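Sulfonium in place of amine on the decarboxylated nucleoside

The source may report more compounds than this note shows. Statements on the series, on what has been measured and on what is new or still open speak of the compounds shown alone.

Of the compounds shown here, two sharing one nucleoside core have been measured in an assay for inhibition of S-adenosylmethionine decarboxylase proenzyme (Rattus norvegicus), in the absence of a further agent; a higher number here means a weaker inhibitor, a lower number a stronger inhibitor. Compound 1 `CN(CCCN)C[C@H]1OC(n2cnc3c(N)ncnc32)[C@H](O)[C@@H]1O` gives 380000 nM, the highest of the two numbers. Compound 2 `C[S+](C)C[C@H]1O[C@@H](n2cnc3c(N)ncnc32)[C@H](O)[C@@H]1O` gives 20000 nM in this assay, a lower number by a gap beyond the scatter; the two structures differ in more than one place, so nothing further is drawn from that pair.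

Compound 3 `C[S+](CCCN)C[C@H]1OC(n2cnc3c(N)ncnc32)[C@H](O)[C@@H]1O` is not yet measured. It differs from compound 1 by a group of 6 heavy atoms (4 carbon, 1 nitrogen, 1 sulfur; no ring) in place of a group of 6 heavy atoms (4 carbon, 2 nitrogen; no ring), on a saturated chain carbon bound to a saturated ring carbon. Going by the values given here, no measured step of this kind exists. In this assay compound 3 is expected to give a clearly lower number than compound 1, a step of a 15-fold lower number from compound 1 to compound 3 (1.18 log units; beyond the scatter), with an estimate of 25000 nM and a range from 6000 nM to 100000 nM.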

Compound 3, inhibition constant: 40000 nM
Estimate against measurement, compound 3: 1.6-fold (0.20 log units) below; low and high end bracket the measured number.
By their numbers in this assay, from the lowest: compounds 2 and 3 (each within the scatter of the next); then compound 1.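

In this assay the step is a 9.5-fold lower number from compound 1 to compound 3 (0.98 log units; beyond the scatter), so this saturated chain carbon bound to a saturated ring carbon responds when the (3-aminopropyl)(methyl)amino group gives way to its sulfur-bearing counterpart. The two groups have the same count of heavy atoms, and the change swaps one nitrogen for sulfur while going from no net charge to a net charge of +1. Nothing available ties the step to the sulfur, to the charge or to any other feature of the change.

The compounds shown leave open whether the step would hold with a longer chain or a carboxylic acid in place of the 3-aminopropyl part of the entering group. They also leave open whether a quaternary ammonium, which carries a net charge of +1 without sulfur, would give a similar step, so the sulfur and the charge cannot be read apart.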